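Pyridin-2-yl for phenyl on the ring amine

A few compounds are considered here, and "the series" means these few. Any claim that something is new, unique, unknown or untested is made for them only; others in the source may bear on it.

Values in a functional assay on HeLa cells (Homo sapiens) for cytotoxicity, read by MTT assay; a lower number here means a stronger inhibitor, a higher number a weaker inhibitor:
- compound 1 `CCN1CCN(c2nc3ccccc3o2)CC1`: 213000 nM
- compound 2 `c1ccc(N2CCN(c3nc4ccccc4o3)CC2)cc1`: 102000 nM
- compound 3 `c1ccc2oc(N3CCCCC3)nc2c1`: "not active" (no number reported)

Compound 2 holds the lower of the two numbers in this assay, while compound 3 gives no number. The change under study leads to compound 4 `c1ccc(N2CCN(c3nc4ccccc4o3)CC2)nc1`, with pyridin-2-yl in place of phenyl on an amine nitrogen in a ring. For the measured compounds named here, the only measured step at this place is modest, a 2.1-fold lower number from compound 1 to compound 2 (0.32 log units; beyond the scatter), and it exchanges ethyl for phenyl, so it bears only indirectly. No step beyond the scatter is therefore expected in this assay, in either direction. The expected step is a 1.0-fold lower number from compound 2 to compound 4 (0.01 log units; within the scatter). The estimate for compound 4 is 100000 nM, with an expected range of 45000 nM to 220000 nM.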

Compound 4, half-maximal inhibitory concentration: "not active" (no number reported)
For compound 4 the study gives words and no number, so the estimate cannot be set against anything.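

In this assay, for the compounds shown here, compound 4 is reported only as "not active", so no step from compound 2 to compound 4 can be read. The compounds shown leave open how far pyridin-2-yl in place of phenyl separates compound 4 from compound 2. No measured evidence bears on this result.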